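The compounds below may be only part of what the source reports. "The series", "measured", "known", "first", "only" and "open" are said of these compounds alone.

Values from a functional assay on DLD-1 cells (Homo sapiens) for cytotoxicity, with a stated time of 48 h (a higher number here means a weaker inhibitor, a lower number a stronger inhibitor), for the measured compounds:
- compound 1 `C[S+]([O-])/C=C/c1cc(=O)c2ccccc2o1` gives 8000 nM
- compound 2 `C[S+]([O-])/C=C/c1cc(=O)c2cc(Cl)ccc2o1` gives 6500 nM
- compound 3 `C[S+]([O-])/C=C/c1cc(=O)c2cc(C#N)ccc2o1` gives > 10000 nM

Compound 3 reads > 10000 nM as a limit, not a number. Going by the values given here, the only comparison between two numbers is a 1.2-fold lower number from compound 1 to compound 2 (0.09 log units; within the scatter) on the shared core. Among the compounds with values here, compound 1 therefore stands level with its one numeric neighbour. The two cyano steps, an at least 1.2-fold higher number from compound 1 to compound 3 (0.09 log units; that floor lies within the scatter) and an at least 1.5-fold higher number from compound 2 to compound 3 (0.18 log units; that floor lies within the scatter) as read against the limit, add no step beyond the scatter.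

Compound 4 `C[S+]([O-])/C=C/c1oc2ccccc2c(=O)c1Cc1ccccc1` differs from compound 1 by benzyl in place of hydrogen on an aromatic carbon. The measured steps bear on this change only loosely: none introduces benzyl, and none substitutes that carbon. Their small size gives no ground for expecting a shift in either direction, so no step beyond the scatter is expected, though the uncertainty is wide. The expected change is a 1.2-fold lower number from compound 1 to compound 4 (0.09 log units; within the scatter) on this estimate. Compound 4 is estimated at 6500 nM with an expected range from 2500 nM to 14000 nM in this assay for now.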

Compound 4, half-maximal inhibitory concentration: 5100 nM
Beside the measured number, compound 4's estimate is 1.3-fold (0.11 log units) above it, within the range that was stated.
By their numbers in this assay, from the lowest: compounds 4, 2 and 1 (each within the scatter of the next). At a limit, above all of these: compound 3.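

In this assay, benzyl in place of hydrogen gives a 1.6-fold lower number from compound 1 to compound 4 (0.20 log units; within the scatter) as the first step read at this aromatic carbon, two atoms from the ring oxygen. This carbon therefore carries a group of 7 heavy atoms, with its six-membered aromatic ring of carbon only, without a step beyond the scatter, whereas the earlier chloro and cyano steps concerned a different place on the shared core. Nothing in the data shown bears on why this step has its size.

Open, going by these compounds, is whether an amine, a carboxylic acid or a longer chain at this carbon would give a step beyond the scatter. Also open, on these data alone, is whether benzyl at this carbon and the chloro group of compound 2, taken together, would read any differently from each change alone.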